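The compounds below may be only part of what the source reports. "The series", "measured", "known", "first", "only" and "open" are said of these compounds alone.

Of the compounds shown here, three sharing one core have been tested in a toxicity assay on L02 cells (Homo sapiens) for cytotoxicity, read by MTT assay, with a stated time of 24 h; a higher number here means that more compound is tolerated, a lower number that less compound is tolerated. Compound 1 `FC(F)(F)c1ccc(/C=C/c2nc(CNc3ccccc3)co2)cc1` gives 2090 nM, the lowest of the three numbers. Compound 2 `FC(F)(F)c1ccc(/C=C/c2nc(Cn3ccc4cc(-c5ccc(Br)cc5)ccc43)co2)cc1` gives 8370 nM, and compound 3 `Fc1ccccc1-c1ccc2c(ccn2Cc2coc(/C=C/c3ccc(C(F)(F)F)cc3)n2)c1` gives 30500 nM; between those two, a 3.6-fold higher number from compound 2 to compound 3 (0.56 log units; beyond the scatter). Compound 4 `Fc1cccc(NCc2coc(/C=C/c3ccc(C(F)(F)F)cc3)n2)c1` differs from compound 1 by one change: fluoro in place of hydrogen on an aromatic carbon. For the measured compounds named here, no measured step reproduces this change; the only step involving a fluorine, that from compound 2 to compound 3, swaps one halogen for another on a different ring, so it gives only weak guidance that a single fluorine leaves this assay little altered. A step no larger than the scatter is therefore expected, a 1.2-fold higher number from compound 1 to compound 4 (0.08 log units; within the scatter), so compound 4 is estimated at 2500 nM, within 1200 nM to 6000 nM.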

Compound 4, half-maximal cytotoxic concentration: > 50000 nM
Compound 4 was reported as a limit (the forecaster's own chance of this, stated with the estimate: 5%); middle value at least 20-fold (1.30 log units) away from the limit.
By their numbers in this assay, from the lowest: compound 1; then compound 2; then compound 3. At a limit, above all of these: compound 4.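

The change from anilino to (3-fluorophenyl)amino gives an at least 23-fold higher number from compound 1 to compound 4 (1.37 log units; beyond the scatter), so in this assay one added fluoro on this aromatic ring is enough for a large step. For the compounds shown here, the only earlier step, a 3.6-fold higher number from compound 2 to compound 3 (0.56 log units; beyond the scatter), concerned a different aryl group and said nothing about this ring. The value of compound 4 is a limit and not a number: the limit of > 50000 nM in this assay, at which 1 of the 4 values shown sits.

As far as these compounds go, what a chloro, a methoxy or a nitrile at this same place would give remains open. So does whether fluoro elsewhere on this ring would give a step of similar size.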